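The source may report more compounds than this note shows. Statements on the series, on what has been measured and on what is new or still open speak of the compounds shown alone.

Compound 1 `CO[C@H]1C[C@H](O[Si](C)(C)C(C)(C)C)O[C@@H](C)/C1=C/C=O`: in a functional assay on the whole organism for inhibition, with Artemia salina as the target (on this read-out higher numbers stand for weaker inhibition of growth and lower numbers for stronger inhibition of growth), compound 1 gives 0.01 ug/mL.
Compound 2 `CO[C@H]1C[C@H](O[Si](C)(C)C(C)(C)C)O[C@@H](C)/C1=C\COC(=O)c1cccnc1`: in this assay compound 2 gives 0.002 ug/mL.

Among these two numbers compound 1 stands highest, so it inhibits growth less strongly than compound 2, and the gap between them lies beyond the scatter. Compound 3 `CO[C@H]1C[C@H](O[Si](C)(C)C(C)(C)C)O[C@@H](C)/C1=C/C(=O)N1CCCCC1` has not been measured. It differs from compound 1 by piperidin-1-yl in place of hydrogen on a carbonyl carbon. Among the measured compounds shown here, no measured pair shows this change, so its effect is unknown here. The step from compound 1 to compound 3 is expected to go toward weaker inhibition by about a number 2 two-fold dilutions higher from compound 1 to compound 3 (beyond the scatter). Compound 3 is therefore estimated at 0.04 ug/mL, within a range from 0.01 ug/mL to 0.3 ug/mL.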

Compound 3, minimum inhibitory concentration: 0.002 ug/mL
Estimate against measurement, compound 3: 4.3 two-fold dilutions above; the measured number lies below the stated range.
By their numbers in this assay, from the lowest: compounds 2 and 3 (each within the scatter of the next); then compound 1.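

In this assay, putting piperidin-1-yl in place of hydrogen on the carbonyl carbon gives a number 2.3 two-fold dilutions lower from compound 1 to compound 3 (beyond the scatter) and turns formyl into (piperidin-1-yl)carbonyl. The formyl group is therefore not needed for inhibition of growth here, and this carbonyl carbon can carry a ring of 6 heavy atoms with stronger inhibition, not weaker. Nothing available explains why this step goes in that direction. On these data alone, whether dimethylamino, morpholin-4-yl or the hydroxyl group of a carboxylic acid on this carbonyl carbon would act like piperidin-1-yl remains open.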